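A few compounds are considered here, and "the series" means these few. Any claim that something is new, unique, unknown or untested is made for them only; others in the source may bear on it.

In an ADME assay on BHK-21 cells (Mesocricetus auratus) for cytotoxicity, read by MTT assay (on this read-out higher numbers stand for lower toxicity in this test and lower numbers for higher toxicity in this test), compound 2 (`CC(=O)c1ccc2c(c1)nc(-c1ccccc1)n2C1CCCCC1`) gives 100000 nM as a number. Compound 3 (`CC(=O)c1ccc2c(c1)nc(-c1ccc(Cl)cc1)n2C1CCCCC1`) reads > 100000 nM and that is a limit of the assay, not a number. It therefore stands at the limit of > 100000 nM in this assay, at which 2 of the 3 values shown sit, with no exact value. Compound 4 (`CC(=O)c1ccc2c(c1)nc(-c1ccc(C(F)(F)F)cc1)n2C1CCCCC1`) differs from compound 3 by trifluoromethyl in place of chloro on an aromatic carbon with trifluoromethyl in place of chloro on an aromatic carbon. Among the compounds with values here, the one measured step at this place is a number no lower from compound 2 to compound 3 (the limit leaves the size open) for chloro in place of hydrogen. Compound 1 (`CC(=O)c1ccc2[nH]c(-c3ccc(C(F)(F)F)cc3)nc2c1`) also carries trifluoromethyl and reads > 100000 nM as a limit. No step beyond the scatter is therefore expected in this assay and the expected size is a number no higher from compound 3 to compound 4 (the limit leaves the size open) in no clear direction. Compound 4 is estimated at 100000 nM with 50000 nM to 200000 nM as its range.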

Compound 4, half-maximal cytotoxic concentration: 33000 nM
Compound 4: middle estimate off by 3.0-fold (0.48 log units), on the high side; the whole stated range lies above it.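

In this assay, this aromatic carbon para to a large group now shows a real change, and a lower number here means higher toxicity in this test. With trifluoromethyl there, the result is a 3.0-fold lower number from compound 2 to compound 4 (0.48 log units; beyond the scatter) against hydrogen and an at least 3.0-fold lower number from compound 3 to compound 4 (0.48 log units; beyond the scatter) against chloro. The group on the aromatic nitrogen also counts, since cyclohexyl in place of hydrogen gives an at least 3.0-fold lower number from compound 1 to compound 4 (0.48 log units; beyond the scatter).

As far as these compounds go, whether a nitrile or an amine at this carbon would also lower the number remains open. The true size of two of these steps also stays open, as they rest on a limit of the assay: the limit of > 100000 nM in this assay, at which 2 of the 4 values shown sit.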